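The source may report more compounds than this note shows. Statements on the series, on what has been measured and on what is new or still open speak of the compounds shown alone.

Series notes. The shared core of compound 1 `Cn1c(=O)c(=O)n(C2CCCC2)c2nc(N/N=C/c3ccco3)ncc21` carries a furan-2-yl group on the carbon with a double bond to nitrogen; in a functional assay on PC-3 cells (Homo sapiens) for antiproliferative activity, read by MTT assay (a higher number here means a weaker inhibitor, a lower number a stronger inhibitor), compound 1 gives 72200 nM. Compound 2 `COc1ccc(/C=N/Nc2ncc3c(n2)n(C2CCCC2)c(=O)c(=O)n3C)c(OC)c1` carries 2,4-dimethoxyphenyl at that place. In this assay compound 2 reaches only a limit of the assay, > 100000 nM, not a number, namely (the limit of > 100000 nM in this assay, at which 1 of the 3 values shown sits). Compound 3 `Cn1c(=O)c(=O)n(C2CCCC2)c2nc(N/N=C/c3cccc([N+](=O)[O-])c3)ncc21` carries 3-nitrophenyl, and in this assay compound 3 gives 20300 nM. Among the two numbers shown compound 3 stands lowest, with compound 1 nearest; the step of a 3.6-fold lower number from compound 1 to compound 3 (0.55 log units; beyond the scatter) lies beyond the scatter, as does an at least 4.9-fold lower number from compound 2 to compound 3 (0.69 log units; beyond the scatter), whereas an at least 1.3-fold higher number from compound 1 to compound 2 (0.14 log units; that floor lies within the scatter) has its floor within the scatter.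

Compound 4 `Cn1c(=O)c(=O)n(C2CCCC2)c2nc(N/N=C/c3cc([N+](=O)[O-])ccc3Cl)ncc21` is not yet measured in this assay. It differs from compound 3 by chloro in place of hydrogen on an aromatic carbon. Every measured step exchanges the whole aryl group on the carbon with a double bond to nitrogen: a 3.6-fold lower number from compound 1 to compound 3 (0.55 log units; beyond the scatter), an at least 4.9-fold lower number from compound 2 to compound 3 (0.69 log units; beyond the scatter) and an at least 1.3-fold higher number from compound 1 to compound 2 (0.14 log units; that floor lies within the scatter). Among the measured compounds shown here, none adds a single substituent to a ring that is otherwise kept, so the step to compound 4 has no direct precedent; the exchanges seen move this assay by modest amounts at most. The expected step of a 1.4-fold lower number from compound 3 to compound 4 (0.13 log units; within the scatter) is therefore small, not beyond the scatter. For compound 4 the estimate in this assay is 15000 nM, within 5000 nM to 50000 nM.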

Compound 4, half-maximal inhibitory concentration: 9260 nM
For compound 4 the middle estimate is 1.6-fold (0.21 log units) above the measured one; measured number inside the range.
By their numbers in this assay, from the lowest: compound 4; then compound 3; then compound 1. At a limit, above all of these: compound 2.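

Among the compounds shown here, on the 3-nitrophenyl group, kept otherwise intact, chloro in place of hydrogen is the first single-substituent change, and on an aromatic carbon ortho to a large group and para to the nitro group it moves this assay beyond the scatter: a 2.2-fold lower number from compound 3 to compound 4 (0.34 log units; beyond the scatter). This place therefore accepts chloro with no loss in this assay, and compound 4 holds the lowest number of the series, with the whole-group exchanges reading a 7.8-fold lower number from compound 1 to compound 4 (0.89 log units; beyond the scatter) and an at least 10-fold lower number from compound 2 to compound 4 (1.03 log units; beyond the scatter). Compound 2 stands at a limit of the assay and not at a number, so that last step gives only a floor: the limit of > 100000 nM in this assay, at which 1 of the 4 values shown sits.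

The compounds shown leave open whether this step belongs to chloro itself or would also appear with fluoro, bromo, methyl or an amine at the same place. They also leave open whether chloro gives a comparable step on a phenyl group without the nitro group, or at another carbon of the same ring.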